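Compound 3: chloro in place of cyano

The source may hold more compounds than are shown below. What is called first, only, known or untested is meant among the compounds shown, and "the series" means these compounds.

Within the data shown here, in an ADME assay for permeability, using PAMPA (on this read-out higher numbers stand for higher permeability and lower numbers for lower permeability), compound 1 `N#Cc1ccc(S(=O)(=O)[C@H]2CN(S(=O)(=O)c3ccc(Cl)cc3Cl)C[C@@]2(O)CO)cc1` gives 450 nm/s and compound 2 `N#Cc1ccc(S(=O)(=O)[C@H]2CN(S(=O)(=O)c3ccc(C#N)cc3Cl)C[C@@]2(O)CO)cc1` gives 350 nm/s, so compound 2 stands within the scatter of the only other measured compound. Compound 3 `N#Cc1ccc(S(=O)(=O)N2C[C@H](S(=O)(=O)c3ccc(Cl)cc3)[C@](O)(CO)C2)c(Cl)c1` differs from compound 2 by one change, chloro in place of cyano on an aromatic carbon, para to a large group. Among the measured compounds shown here, the one measured step bearing on this is the reverse exchange elsewhere in the molecule, a 1.3-fold lower number from compound 1 to compound 2 (0.11 log units; within the scatter). No step beyond the scatter is therefore expected, and the estimated step is a 1.2-fold higher number from compound 2 to compound 3 (0.08 log units; within the scatter). For compound 3 the expected value is 420 nm/s, with an estimated range of 210 nm/s to 800 nm/s.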

Compound 3, apparent permeability: 350 nm/s
The estimate for compound 3 lay 1.2-fold (0.08 log units) above the measured number; the range from low to high includes it.
By their numbers in this assay, from the lowest: compounds 2, 3 and 1 (each within the scatter of the next).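

Working notes: in this assay the swap from 4-cyanophenyl to 4-chlorophenyl gives no change at the digits printed from compound 2 to compound 3 (within the scatter) and thus extends the exchange of cyano and chloro to a second aromatic ring of the series. The earlier exchange, a 1.3-fold lower number from compound 1 to compound 2 (0.11 log units; within the scatter) on the other aromatic ring, is also within the scatter, so at both places this pair of groups leaves the read-out within the scatter. No measurement in hand accounts for this result.

Open, on these data alone, is whether an amine or a carboxylic acid at this position would give a step beyond the scatter in this assay at all.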